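Methyl in place of methoxy at the hydroxybenzamide

This account rests on a few compounds, and the source may have more. Where it says the series, first, only, none or still open, it means among the compounds named here.

Compound 1 `COc1ccc(-c2cc(NC(=O)c3ccccc3O)c[nH]c2=O)cc1` gives > 100000 nM in an ADME assay on HepG2 2.2.15 cells (Homo sapiens) for cytotoxicity, read by CCK-8 assay, with a stated time of 8 days (a higher number here means that more compound is tolerated, a lower number that less compound is tolerated), which is a limit of the assay.
Compound 2 `COc1ccc(-c2cc(NC(=O)c3ccc(OC)cc3O)c[nH]c2=O)cc1` gives 49900 nM.
Compound 3 `COc1ccc(C(=O)Nc2c[nH]c(=O)c(-c3cccc(C)c3)c2)c(O)c1` gives > 100000 nM, again a limit of the assay.

Compound 3 thus sits at the upper limit, as does compound 1; only compound 2 yields a number. Compound 4 `Cc1cccc(-c2cc(NC(=O)c3ccc(C)cc3O)c[nH]c2=O)c1` differs from compound 3 by methyl in place of methoxy on an aromatic carbon. The closest measured step is an at least 2.0-fold lower number from compound 1 to compound 2 (0.30 log units; that floor lies within the scatter), where adding a methoxy lowered the number, though only to the floor of the scatter; an at least 2.0-fold higher number from compound 2 to compound 3 (0.30 log units; that floor lies within the scatter) returned to the limit. Removing the methoxy in favor of methyl is therefore expected to leave compound 4 at or near the limit, with a number no higher from compound 3 to compound 4 (the limit leaves the size open) expected. Compound 4 is estimated at 100000 nM, between 50000 nM and 200000 nM.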

Compound 4, half-maximal cytotoxic concentration: 75000 nM
For compound 4 the middle estimate is 1.3-fold (0.12 log units) above the measured one; the measured number falls inside the stated range.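

At this position, para to a large group, methyl in place of methoxy gives an at least 1.3-fold lower number from compound 3 to compound 4 (0.12 log units; that floor lies within the scatter) in this assay. Compound 4 therefore has a measured number on the 3-methylphenyl series, which compound 3 does not provide. The step shows only a floor that lies within the scatter, and its true size stays unknown because compound 3 sits at a limit: the limit of > 100000 nM in this assay, at which 2 of the 4 values shown sit.

The compounds shown leave open how an amine, a carboxylic acid or a longer chain at this position would read in this assay.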